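Triazolopyrimidine series: alkylamino variation at the aromatic nitrogen

A few compounds are considered here, and "the series" means these few. Any claim that something is new, unique, unknown or untested is made for them only; others in the source may bear on it.

Measured so far:
Compound 1 `CCNc1nc(-c2ccccc2)nc2c1nnn2Cc1ccccc1F` — 11 nM
Compound 2 `CCCCNc1nc(-c2ccccc2)nc2c1nnn2Cc1ccccc1F` — 4.3 nM
Compound 3 `CCCCNc1nc(-c2ccccc2)nc2c1nnn2Cc1ccccc1C(F)(F)F` — 6.5 nM

In an assay on Cerebral cortex for displacement of a labelled ligand from adenosine receptor A1 (Bos taurus) (on this read-out higher numbers stand for weaker inhibition and lower numbers for stronger inhibition), compound 2 gives the lowest number of the three. Compound 3 is nearest, a 1.5-fold higher number from compound 2 to compound 3 (0.18 log units; within the scatter), so the two are not separable. Among the compounds with values here, compound 1 sits furthest, a 2.6-fold lower number from compound 1 to compound 2 (0.41 log units; beyond the scatter), where the only change is the longer chain on the amine.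

Compound 4 `Fc1ccccc1Cn1nnc2c(NC3CC3)nc(-c3ccccc3)nc21` is not yet measured. It differs from compound 2 by cyclopropyl in place of butyl on a nitrogen on an aromatic ring. Within the data shown here, only the step from compound 1 to compound 2 bears on this, since it alone alters the same amine substituent; the change from compound 2 to compound 3 sits elsewhere and offers nothing. As far as these compounds go, that single step is modest, and a ring is untested here, so a small move toward a higher number, or none beyond the scatter, is expected: a 1.4-fold higher number from compound 2 to compound 4 (0.14 log units; within the scatter). Compound 4 is estimated at 6 nM, range 2.5 nM to 15 nM.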

Compound 4, inhibition constant: 15 nM
Compound 4: the middle estimate sits 2.5-fold (0.40 log units) below what was measured; the range from low to high includes it.
By their numbers in this assay, from the lowest: compounds 2, 3, 1 and 4 (each within the scatter of the next, the first and the last beyond it).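

At the amine nitrogen, a ring is not a neutral swap for the chain: butylamino to cyclopropylamino gives a 3.5-fold higher number from compound 2 to compound 4 (0.54 log units; beyond the scatter) and so loses the low number seen with butyl. Against the ethyl analogue, the same ring gives a 1.4-fold higher number from compound 1 to compound 4 (0.13 log units; within the scatter) and cannot be told apart from it, so cyclopropyl and ethyl stand level here. Nothing at hand explains this difference.

As far as these compounds go, it remains open whether a larger ring such as cyclohexyl, or a branched chain such as isobutyl, would match butyl. Also open, from the compounds shown here alone, is whether cyclopropylamino behaves the same with trifluoromethyl on the benzyl ring.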